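The compounds below may be only part of what the source reports. "The series", "measured", "known", "first", "only" and "open" are said of these compounds alone.

Measured compounds:
compound 1, `COc1nc(C)c(CCO)c(OC)n1`: > 100000 nM
compound 2, `COc1nc(C)c(CCF)c(OC)n1`: "not determined" (no result reported)
compound 3, `COc1nc(Cl)nc(C)c1CCF`: "not determined" (no result reported)

These three share one core and were tested for how strongly they hold back the growth of a leukaemia cell line. In a functional assay on MOLT-4 cells (Homo sapiens) for antiproliferative activity, read by MTT assay, with a stated time of 24 h (on this read-out higher numbers stand for weaker inhibition and lower numbers for stronger inhibition), compound 1 gives > 100000 nM, which is a limit of the assay and not a number (the limit of > 100000 nM in this assay, at which 1 of the 3 values shown sits). Compound 2 has no result in this assay, "not determined" (no result reported). The same holds for compound 3, "not determined" (no result reported). Compound 2 therefore stands without a number of its own: of the three entries shown, one is a limit and one other also lacks a number.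

Compound 4, `COc1nc(C)c(CCCl)c(OC)n1`, is still to be measured. It differs from compound 2 by chloro in place of fluoro on a saturated chain carbon, two bonds along the chain from an aromatic carbon. For the measured compounds named here, no measured pair of this kind is available, so the size of the step is open. Going by the values given here, since the only number-bearing entry, compound 1, sits at the limit (the limit of > 100000 nM in this assay, at which 1 of the 3 values shown sits), any step from compound 2 to compound 4 in this assay is expected to be none beyond the scatter. Compound 4 is expected to give about 150000 nM, within a range from 30000 nM to 600000 nM, most likely reported again only as a limit.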

Compound 4, half-maximal inhibitory concentration: > 100000 nM
Compound 4 gave a limit, no number (the forecaster's own chance of this, stated with the estimate: 80%); the middle value lies beyond the limit too.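

Compound 1 and compound 4 each sit at a limit rather than at a number, so no step between them can be read: the limit of > 100000 nM in this assay, at which 2 of the 4 values shown sit.

The compounds shown leave open whether any group on this chain of the shared core would give a readable number in this assay.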